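Sulfonamide variation on a shared core: methyl for trifluoromethyl

The source may hold more compounds than are shown below. What is called first, only, known or untested is meant among the compounds shown, and "the series" means these compounds.

Measured so far:
compound 1 `O=S(=O)(Nc1ccc(-c2nc3ccccc3o2)cc1)c1cccs1` — 63000 nM
compound 2 `O=S(=O)(Nc1ccc(-c2nc3ccccc3o2)cc1)c1cccc(C(F)(F)F)c1` — 57000 nM

Both measurements come from an assay on cells for inhibition of HSP60/HSP10 (Homo sapiens), with a stated time of 60 min; a higher number here means a weaker inhibitor, a lower number a stronger inhibitor. Compound 2 carries the lower of the two numbers, but its nearest neighbour, compound 1, lies within the scatter of it, so the two cannot be ordered and neither can be called the stronger inhibitor. Both sit in the same weak region.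

Compound 3 `Cc1cccc(S(=O)(=O)Nc2ccc(-c3nc4ccccc4o3)cc2)c1` is the next structure to be measured. It differs from compound 2 by methyl in place of trifluoromethyl on an aromatic carbon. Among the compounds with values here, no step between two measured compounds is available, so nothing shows how this assay responds to a change of this kind. With both known values close together and the change confined to a single substituent, the expected step from compound 2 to compound 3 is none beyond the scatter, a 1.2-fold higher number from compound 2 to compound 3 (0.09 log units; within the scatter). Compound 3 is estimated at 70000 nM, with a range from 25000 nM to 200000 nM; a value reported only as a limit is possible.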

Compound 3, half-maximal inhibitory concentration: > 100000 nM
Compound 3: a limit, no number; the forecaster's own chance of this, stated with the estimate: 20%; at least 1.4-fold (0.15 log units) between middle value and limit.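

In this assay compound 3 gives > 100000 nM, which is a limit and not a number, so the series now has a member without a measured value. Methyl in place of trifluoromethyl on this aromatic carbon, meta to a large group, gives an at least 1.7-fold higher number from compound 2 to compound 3 (0.24 log units; that floor lies within the scatter), and 3-methylphenyl in place of thiophen-2-yl on a sulfonyl sulfur gives an at least 1.5-fold higher number from compound 1 to compound 3 (0.20 log units; that floor lies within the scatter). Both floors lie within the scatter, so the position is not yet shown to respond to either change, nor shown to be indifferent to it, and the readout for this series already touches the ceiling of what can be read: the limit of > 100000 nM in this assay, at which 1 of the 3 values shown sits.

On these data alone, how far compound 3 lies past its limit stays open. Also open, as far as these compounds go, is whether an amine or a carboxylic acid on this aromatic carbon would move the number down from the weak region.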